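Swapping the Amine for an Aldehyde: Cytotoxicity Outlook

The compounds below may be only part of what the source reports. "The series", "measured", "known", "first", "only" and "open" are said of these compounds alone.

Two compounds share a core carrying an ester-tipped ether chain on an aromatic ring, and differ only in the amine attached through a methylene on that ring. Compound 1 `CCOC(=O)CCCCCOc1cccc(CNC(C)C)c1` carries the branched amine, compound 2 `CCCNCc1cccc(OCCCCCC(=O)OCC)c1` the straight-chain one. In an ADME assay on HEK293 cells (Homo sapiens) for cytotoxicity, read by CellTiter-Glo and resazurin assay, with a stated time of 72 h (a lower number here means that less compound is needed, a higher number that more compound is needed for the effect), compound 1 gives > 26000 nM, which is a limit of the assay rather than a number. In this assay compound 2 likewise gives > 26000 nM, again only a limit. The step that the two limits leave unreadable from compound 1 to compound 2 therefore cannot be sized, because the limit of > 26000 nM in this assay, at which 2 of the 2 values shown sit, holds both values. Compound 2 thus stands at the limit, with no number to place it more exactly. Compound 3 `CCOC(=O)CCCCCOc1cccc(C=O)c1` differs from compound 2 by formyl in place of (propylamino)methyl on an aromatic carbon. Going by the values given here, no measured step bears directly on this change; the only step available, a step that the two limits leave unreadable from compound 1 to compound 2, is unreadable. The expectation for compound 3 is therefore no readable change, a step that the limit leaves unreadable from compound 2 to compound 3, most likely again a limit. Compound 3 is estimated at 40000 nM, between 15000 nM and 120000 nM.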

Compound 3, half-maximal effective concentration: > 26000 nM
Compound 3: only a limit was reported; the forecaster's own chance of this, stated with the estimate: 80%; the middle value does not contradict the limit.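

Like compound 1 and compound 2, compound 3 gives only a limit in this assay, so no step among these three compounds can be read, because all three rest on the same limit: the limit of > 26000 nM in this assay, at which 3 of the 3 values shown sit. The compounds shown leave open whether replacing either amine group with formyl changes the concentration needed for cytotoxicity at all.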